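A few compounds are considered here, and "the series" means these few. Any claim that something is new, unique, unknown or untested is made for them only; others in the source may bear on it.

In an in vitro functional assay on cells for antagonist activity at transient receptor potential cation channel subfamily V member 1 (Homo sapiens), read by reporter gene assay and calcium flux (on this read-out lower numbers stand for stronger inhibition and higher numbers for weaker inhibition), three compounds set the scene. Compound 1 `O=C(Nc1ccc(Cl)c(C(F)(F)F)c1)Nc1cccc2ccc(O)c(F)c12` gives 9.1 nM, compound 2 `O=C(Nc1ccc(Cl)c(C(F)(F)F)c1)Nc1ccc2ccc(O)cc2c1` gives 130 nM, and compound 3 `Nc1ccc2cccc(NC(=O)Nc3ccc(Cl)c(C(F)(F)F)c3)c2c1` gives 34 nM. Compound 3 therefore stands second highest of the three, its number lying a step beyond the scatter above that of compound 1 and a step beyond the scatter below that of compound 2. Compound 4 `NS(=O)(=O)c1ccc2cccc(NC(=O)Nc3ccc(Cl)c(C(F)(F)F)c3)c2c1` has not been measured; it differs from compound 3 by sulfamoyl in place of amino on an aromatic carbon. Going by the values given here, no measured pair shows this change, so the direction rests on the change alone, and a moderate loss in this assay is expected. Compound 4 is expected to give 80 nM, between 20 nM and 320 nM. The expected step is a 2.4-fold higher number from compound 3 to compound 4 (0.37 log units; beyond the scatter).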

Compound 4, half-maximal inhibitory concentration: 710 nM
Beside the measured number, compound 4's estimate is 8.9-fold (0.95 log units) below it; measured number above the stated range.
By their numbers in this assay, from the lowest: compound 1; then compound 3; then compound 2; then compound 4.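

In this assay the aromatic carbon carrying the amino group of compound 3 proves highly sensitive to what sits on it: sulfamoyl in place of amino brings a 21-fold higher number from compound 3 to compound 4 (1.32 log units; beyond the scatter) and leaves compound 4 with the highest number of the four. Going by these compounds alone, this is the first change in a single place, so the earlier compounds could not show this. Nothing measured here explains the loss.

On these data alone, whether a carboxylic acid or an acetamide on this carbon would track amino or sulfamoyl remains open.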